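A few compounds are considered here, and "the series" means these few. Any claim that something is new, unique, unknown or untested is made for them only; others in the source may bear on it.

In a functional assay on KB cells (Homo sapiens) for antiproliferative activity, read by MTT assay, with a stated time of 72 h (a higher number here means a weaker inhibitor, a lower number a stronger inhibitor), compound 1 (`O=C1C=C(N2CCN(c3ccccc3Cl)CC2)C(=O)c2c(O)cccc21`) gives 4400 nM. Compound 2 (`O=C1C=C(N2CCC(c3ccccc3)CC2)C(=O)c2c(O)cccc21`) gives 2200 nM, which lies within the usual scatter of compound 1, so neither can be ranked above the other. Compound 3 (`Cc1ccccc1C1CCN(C2=CC(=O)c3cccc(O)c3C2=O)CC1`) differs from compound 2 by one small change, methyl in place of hydrogen on an aromatic carbon. For the measured compounds named here, no measured pair shows what this change does in this assay, so no step beyond the scatter is expected, in either direction. The expected change is a 1.1-fold lower number from compound 2 to compound 3 (0.04 log units; within the scatter). The estimate for compound 3 is 2000 nM, with an expected range of 700 nM to 6000 nM.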

Compound 3, half-maximal inhibitory concentration: 4400 nM
Beside the measured number, compound 3's estimate is 2.2-fold (0.34 log units) below it, within the range that was stated.
By their numbers in this assay, from the lowest: compounds 2, 1 and 3 (each within the scatter of the next).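

Swapping hydrogen for methyl on an aromatic carbon ortho to a large group, which turns phenyl into 2-methylphenyl, gives a 2.0-fold higher number from compound 2 to compound 3 (0.30 log units; within the scatter) in this assay. For the compounds shown here, this pair is the first measured reading of the change, and it shows that a methyl at this position leaves the antiproliferative reading within what repeated measurements would scatter by. No outside evidence bears on this result. The compounds shown leave open whether a methoxy group or an amine at this same position would give a step beyond the scatter.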